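Methoxy placement on a bithiophene amidine and red-cell lysis

A few compounds are considered here, and "the series" means these few. Any claim that something is new, unique, unknown or untested is made for them only; others in the source may bear on it.

Compounds measured so far:
compound 1 `N=C(N)c1ccc(-c2ccc(-c3ccccc3)s2)s1`: "non-toxic" (no number reported)
compound 2 `COc1ccc(-c2ccc(-c3ccc(C(=N)N)s3)s2)cc1`: 17.3%

Compound 1 was examined in an ADME assay on cells (Erythrocyte, Homo sapiens) for activation, read by hemolysis, with a stated time of 30 min, tested at 1.25 mM (on this read-out higher numbers stand for a stronger effect at the one concentration tested and lower numbers for a weaker effect), where compound 1 is recorded as "non-toxic" (no number reported), a description rather than a number; where compound 1 stands on the scale of percentages is therefore not known. Compound 2, which carries a methoxy group on the outer six-membered ring, gives 17.3% in this assay, a modest read-out.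

Compound 3 `COc1cccc(-c2ccc(-c3ccc(C(=N)N)s3)s2)c1` is not yet measured in this assay. Compound 3 differs from compound 1 by methoxy in place of hydrogen on an aromatic carbon, the new group sitting on an aromatic carbon of a six-membered aromatic ring of carbon only. Within the data shown here, no step between measured compounds is available for this change, so the size of its effect in this assay is not known from the data; compound 2 suggests that a methoxy group on that ring is compatible with a low read-out, and the step from compound 1 to compound 3 is expected to be small, with no direction that would clearly exceed the scatter.

Compound 3 is expected to give about 14% in this assay, within a range of 2% to 32%.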

Compound 3, a percentage reported as activity, at one concentration (the size of the read-out at that concentration, not a potency): 3.1%
Estimate against measurement, compound 3: 10.9 percentage points above; the measured number falls inside the stated range.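

In this assay, among these compounds, compound 3 gives 3.1%, while compound 1 is recorded as "non-toxic" (no number reported), and no step from compound 1 to compound 3 can be read. Nothing available bears on this result. The compounds shown leave open how large the effect of methoxy in place of hydrogen is on this read-out.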